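The source may report more compounds than this note shows. Statements on the series, on what has been measured and on what is new or still open speak of the compounds shown alone.

Measured so far in a functional assay on MCF7 cells (Homo sapiens) for antiproliferative activity, read by MTT assay, with a stated time of 48 h; a lower number here means a stronger inhibitor, a higher number a weaker inhibitor:
compound 1, `COc1ccc2c(/C=C/C(=O)c3cc(OC)c(OC)c([N+](=O)[O-])c3)c[nH]c2c1`, gives 662 nM.
compound 2, `COc1cc(C(=O)/C=C/c2c[nH]c3ccccc23)cc([N+](=O)[O-])c1OC`, gives 1290 nM.
compound 3, `COc1ccc2c(/C=C(\C)C(=O)c3cc(OC)c(OC)c([Se]C)c3)c[nH]c2c1`, gives 35 nM.

Compound 1 and compound 2 differ in one place: hydrogen in place of methoxy on an aromatic carbon. That change gave a 1.9-fold higher number from compound 1 to compound 2 (0.29 log units; within the scatter), a step that stays within the usual scatter of repeated measurements. Compound 4, `COc1cc(C(=O)/C(C)=C/c2c[nH]c3ccccc23)cc([Se]C)c1OC`, has not yet been measured. It differs from compound 3 by hydrogen in place of methoxy on an aromatic carbon, the same change at the same place as between compound 1 and compound 2. How the core of compound 3 differs from the core of compound 1 is not broken down here. Within the data shown here, the only measured example of this change is a 1.9-fold higher number from compound 1 to compound 2 (0.29 log units; within the scatter). On that rests the expectation for compound 4 of a similarly small step, a 1.7-fold higher number from compound 3 to compound 4 (0.23 log units; within the scatter). Compound 4 is therefore estimated at 60 nM in this assay. Four of five repeat measurements of compound 4 are expected to fall between 25 nM and 150 nM.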

Compound 4, half-maximal inhibitory concentration: 59 nM
The estimate for compound 4 lay 1.0-fold (0.01 log units) above the measured number; the range from low to high includes it.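

In this assay, putting hydrogen in place of methoxy on an aromatic carbon gave a 1.7-fold higher number from compound 3 to compound 4 (0.23 log units; within the scatter), and this step can be set beside the earlier one on a different core: the same change on two cores in this assay, a 1.9-fold higher number (0.29 log units; within the scatter) from compound 1 to compound 2 and a 1.7-fold higher number (0.23 log units; within the scatter) from compound 3 to compound 4, 1.2-fold (0.06 log units) apart, within the scatter of two such steps. In these two pairs, then, the change carries from one core to the other with a step of similar size, and neither step rises above the usual scatter of repeated measurements. Two pairs do not show that the same would hold on other cores in this series, and they say nothing about why the step stays so small.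

At this place on the ring, the compounds shown carry only hydrogen or methoxy. Going by these compounds, how an amine, a hydroxyl group or a longer chain such as ethoxy would compare remains open.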